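Aryl group change on the aromatic carbon: expectation for compound 3

The source may report more compounds than this note shows. Statements on the series, on what has been measured and on what is new or still open speak of the compounds shown alone.

Compound 1 `COc1cccc(-c2cc(-c3cc(C(C)C)c(O)cc3C)[nH]c(=O)c2C#N)c1` and compound 2 `Cc1cc(O)c(C(C)C)cc1-c1cc(-c2cccs2)c(C#N)c(=O)[nH]1` share one core and differ only in the group on an aromatic carbon. In a functional assay for inhibition, tested at 80 ug/mL (a higher number here means a stronger effect of the compound at the concentration tested, a lower number a weaker effect), compound 1 gives 43% and compound 2 gives 63%. Among the measured compounds shown here, compound 2 stands highest of the two numbers so far; its nearest neighbour is compound 1, and the step of a number 20 percentage points higher from compound 1 to compound 2 (beyond the scatter) is a modest rise beyond the scatter. Compound 3 `COc1ccc(-c2cc(-c3cc(C(C)C)c(O)cc3C)[nH]c(=O)c2C#N)c(OC)c1` is not yet measured. Relative to compound 2 the change is 2,4-dimethoxyphenyl in place of thiophen-2-yl on an aromatic carbon. For the measured compounds named here, the only measured step that bears on it is a number 20 percentage points higher from compound 1 to compound 2 (beyond the scatter), which replaced a methoxyphenyl by thiophen-2-yl and gained modestly; compound 3 moves back from thiophen-2-yl to a methoxy-bearing phenyl, although 2,4-dimethoxyphenyl is not 3-methoxyphenyl, so no measured pair gives this exact change. Going by the values given here, the expected outcome in this assay is therefore a drop of about the same size, a number 21 percentage points lower from compound 2 to compound 3 (beyond the scatter), with wide uncertainty because a number 20 percentage points higher from compound 1 to compound 2 (beyond the scatter) is the single guide. Compound 3 is estimated at 42%, within a range of 25% to 60%.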

Compound 3, a percentage reported as inhibition, at one concentration (the size of the read-out at that concentration, not a potency): 55%
Estimate against measurement, compound 3: 13 percentage points below; low and high end bracket the measured number.
By their numbers in this assay, from the lowest: compound 1; then compounds 3 and 2 (each within the scatter of the next).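

In this assay, the carbon opposite the ring nitrogen accepts 2,4-dimethoxyphenyl in place of thiophen-2-yl with a number 8 percentage points lower from compound 2 to compound 3 (within the scatter), so at this position a six-membered aromatic ring of carbon only, with its 10 heavy atoms, reads level with the five-membered aromatic ring that carries sulfur. The rise seen earlier on leaving 3-methoxyphenyl therefore does not separate thiophen-2-yl from phenyl groups as a class: 2,4-dimethoxyphenyl in place of 3-methoxyphenyl gives a number 12 percentage points higher from compound 1 to compound 3 (beyond the scatter), which shows that the arrangement of methoxy groups on the phenyl ring changes the read-out at this carbon. No measured property of these groups is available to account for either step.

Still open, as far as these compounds go, is how an unsubstituted phenyl, or a phenyl carrying an amine or a carboxylic acid, would read at this carbon, which would help show whether one methoxy group or the other drives the step between the two phenyl groups. All three numbers also come from a single concentration, so they show only a stronger or weaker effect at that concentration and say nothing about how the compounds would compare at any other.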